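This account rests on a few compounds, and the source may have more. Where it says the series, first, only, none or still open, it means among the compounds named here.

Measured so far:
compound 1 `CC(C)c1ccc(NC(=O)N2CCN(c3ncccc3Br)CC2)cc1` — 4.6 nM
compound 2 `CCCCc1ccc(NC(=O)N2CCN(c3ncccc3Cl)CC2)cc1` — 117 nM

In a functional assay on HEK293 cells for antagonist activity at transient receptor potential cation channel subfamily V member 1 (Rattus norvegicus) (a higher number here means a weaker inhibitor, a lower number a stronger inhibitor), compound 2 gives the higher of the two numbers: compound 1 gives 4.6 nM, a far lower number, and the gap between the two is beyond the scatter. The two compounds differ in more than one place, so no single step can be read from them.

Compound 3 `O=C(Nc1ccc(Br)cc1)N1CCN(c2ncccc2Cl)CC1` has not yet been measured. It comes from compound 2 by one change, (bromo in place of butyl on an aromatic carbon). For the measured compounds named here, no step of this exact kind stands among the measured compounds, so its size is open. Since compound 1, which carries a smaller group at the same position, gives 4.6 nM, the expectation is that compound 3 will give a lower number than compound 2, and that the step of a 5.9-fold lower number from compound 2 to compound 3 (0.77 log units; beyond the scatter) will lie beyond the scatter. Compound 3 is therefore estimated at 20 nM, within a range from 4 nM to 100 nM.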

Compound 3, half-maximal inhibitory concentration: 491 nM
For compound 3 the middle estimate is 25-fold (1.39 log units) below the measured one; measured number outside the range, above it.
By their numbers in this assay, from the lowest: compound 1; then compound 2; then compound 3.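

Replacing butyl with bromo on this aromatic carbon, para to a large group, gives a 4.2-fold higher number from compound 2 to compound 3 (0.62 log units; beyond the scatter) in this assay. For the compounds shown here, this is the first single change that can be read at this position, and it shows that the position responds to what it carries: with the rest of the molecule unchanged, the butyl compound is the stronger inhibitor of the pair. No measurement shown here accounts for this step.

Compound 1 differs from compound 2 and compound 3 in more than one place, so the steps to it cannot be read, and two groups at this position do not make a trend. Going by these compounds, how a fluoro, a tert-butyl or a longer chain such as hexyl would fare on the same core remains open.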